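This account rests on a few compounds, and the source may have more. Where it says the series, first, only, none or still open, it means among the compounds named here.

In an ADME assay (liver) for metabolic stability, with Liver microsome (Rattus norvegicus) as the target, using microsomes and NADPH, with a stated time of 30 min, tested at 1 uM (on this read-out lower numbers stand for slow clearance and higher numbers for fast clearance), three compounds sharing one core have been measured. Compound 1 `COc1cc(C(O)(C(F)(F)F)C(F)(F)F)cnc1N1CCN(S(=O)(=O)c2ccc(N)nc2)CC1` gives < 14 mL.min-1.g-1, which is a limit of the assay and not a number. Compound 2 `CC(C)(C)n1cc(-c2cc(C(O)(C(F)(F)F)C(F)(F)F)cnc2N2CCN(S(=O)(=O)c3ccc(N)nc3)CC2)cn1` reads 459 mL.min-1.g-1. Compound 3 `Nc1ccc(S(=O)(=O)N2CCN(c3ncc(C(O)(C(F)(F)F)C(F)(F)F)cc3-c3ccoc3)CC2)cn1` reads 57 mL.min-1.g-1, the lower of the two actual numbers. The next compound, compound 4 `CS(=O)(=O)Nc1cccc(-c2cc(C(O)(C(F)(F)F)C(F)(F)F)cnc2N2CCN(S(=O)(=O)c3ccc(N)nc3)CC2)c1`, changes the same place on the core: 3-(methanesulfonamido)phenyl in place of furan-3-yl on an aromatic carbon, with 3-(methanesulfonamido)phenyl in place of furan-3-yl on an aromatic carbon. All three measured steps bear on this place. Replacing methoxy there gave a large rise, an at least 32-fold higher number from compound 1 to compound 2 (1.51 log units; beyond the scatter), and a rise of at least modest size, an at least 4.0-fold higher number from compound 1 to compound 3 (0.60 log units; beyond the scatter). Exchanging one of the new groups for the other gave a modest fall, an 8.1-fold lower number from compound 2 to compound 3 (0.91 log units; beyond the scatter). The read-out therefore responds clearly to the group at this place. A modest rise in this assay is expected rather than a fall, with compound 2 at 459 mL.min-1.g-1 as a guide to how high it could go. The expected change is a 2.3-fold higher number from compound 3 to compound 4 (0.36 log units; beyond the scatter). For compound 4 the estimate is 130 mL.min-1.g-1, with an expected range of 40 mL.min-1.g-1 to 420 mL.min-1.g-1.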

Compound 4, intrinsic clearance in microsomes: 81 mL.min-1.g-1
The estimate for compound 4 lay 1.6-fold (0.21 log units) above the measured number; the measured number falls inside the stated range.
By their numbers in this assay, from the lowest: compounds 3 and 4 (each within the scatter of the next); then compound 2. At a limit, below all of these: compound 1.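

In this assay, 3-(methanesulfonamido)phenyl in place of furan-3-yl gives a 1.4-fold higher number from compound 3 to compound 4 (0.15 log units; within the scatter), so a larger group with a six-membered aromatic ring and a hydrogen-bond donor leaves the read-out where the five-membered ring had it. The same group stands well apart from 1-(tert-butyl)-1H-pyrazol-4-yl, with a 5.7-fold lower number from compound 2 to compound 4 (0.75 log units; beyond the scatter), which leaves compound 2 alone at the high end among the three aromatic groups. Against methoxy the step is an at least 5.7-fold higher number from compound 1 to compound 4 (0.76 log units; beyond the scatter), and it is only a bound, since the value of compound 1 is a limit of the assay: the limit of < 14 mL.min-1.g-1 in this assay, at which 1 of the 4 values shown sits.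

On these data alone, whether the high number of compound 2 goes with the tert-butyl group or with the pyrazole ring stays open. So does how an unsubstituted phenyl, an amine or a carboxylic acid at this place would read.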